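The source may report more compounds than this note shows. Statements on the series, on what has been measured and on what is new or still open speak of the compounds shown alone.

Measured compounds:
Compound 1, `Cc1cnc(Nc2ccc(S(N)(=O)=O)cc2)nc1Nc1nc2ccccc2s1`, in a functional assay on PC-3 cells (Homo sapiens) for antiproliferative activity, read by MTT assay, with a stated time of 48 h (on this read-out higher numbers stand for weaker inhibition and lower numbers for stronger inhibition), gives > 50000 nM, a limit of the assay.
Compound 2, `Cc1cnc(Nc2ccc(Cl)cc2)nc1Nc1nc2ccccc2s1`, in this assay gives > 50000 nM, a limit of the assay.
Compound 3, `COc1cccc(Nc2ncc(C)c(Nc3nc4ccccc4s3)n2)c1`, in this assay gives > 50000 nM, a limit of the assay.

Compound 3 stands at the limit, as do the other two values shown; all three sit at the limit of > 50000 nM in this assay, at which 3 of the 3 values shown sit. The steps among the measured compounds tell nothing about size: a step that the two limits leave unreadable from compound 1 to compound 2 and a step that the two limits leave unreadable from compound 2 to compound 3 are both unreadable, since both ends are limits.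

Compound 4, `Cc1cnc(Nc2ccc(F)cc2)nc1Nc1nc2ccccc2s1`, is not yet measured. It differs from compound 3 in one place: 4-fluorophenyl in place of 3-methoxyphenyl on a nitrogen on an aromatic ring. Going by the values given here, the closest comparison is compound 2, which carries a 4-chlorophenyl on the same nitrogen and also sits at the limit, so no measured step gives a readable direction or size for this change.

With every related compound at the limit, compound 4 is expected to give 100000 nM in this assay, within 50000 nM to 300000 nM, most likely reported again only as a limit. The expected step from compound 3 to compound 4 is a step that the limit leaves unreadable from compound 3 to compound 4, that is, none beyond the scatter.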

Compound 4, half-maximal inhibitory concentration: > 50000 nM
Compound 4: a limit, no number; the forecaster's own chance of this, stated with the estimate: 85%; the middle value is on the limit's open side.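

The steps to compound 4 from compound 1, compound 2 and compound 3 cannot be read, because each end is a limit and not a number: the limit of > 50000 nM in this assay, at which 4 of the 4 values shown sit.
The compounds shown leave open whether any group on that nitrogen gives a readable number in this assay and how large these steps really are.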